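The source may report more compounds than this note shows. Statements on the series, on what has been measured and on what is new or still open speak of the compounds shown alone.

Two analogues of the shared core have been run so far. Compound 1 `Cc1ccc(Cl)cc1-n1nncc1CN1C(=O)C2(C(C#N)=C(N)Oc3c(N)cc4nc5ccccc5nc4c32)c2ccccc21` carries 5-chloro-2-methylphenyl on the aromatic nitrogen. In a functional assay on A549 cells (Homo sapiens) for antiproliferative activity, read by MTT assay, with a stated time of 48 h (a higher number here means a weaker inhibitor, a lower number a stronger inhibitor), compound 1 gives > 50000 nM, a limit of the assay rather than a number. Compound 2 `N#CC1=C(N)Oc2c(N)cc3nc4ccccc4nc3c2C12C(=O)N(Cc1cnnn1-c1ccc([N+](=O)[O-])cc1[N+](=O)[O-])c1ccccc12` carries 2,4-dinitrophenyl at the same place. In this assay compound 2 gives > 50000 nM, again a limit and not a number. The step that the two limits leave unreadable from compound 1 to compound 2 therefore cannot be read, since both ends sit at the limit of > 50000 nM in this assay, at which 2 of the 2 values shown sit. Compound 2 thus stands only at that limit, with no numerical value recorded on either side of it.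

Compound 3 `Cc1cc(C)c(-n2nncc2CN2C(=O)C3(C(C#N)=C(N)Oc4c(N)cc5nc6ccccc6nc5c43)c3ccccc32)c(C)c1` differs from compound 2 by 2,4,6-trimethylphenyl in place of 2,4-dinitrophenyl on an aromatic nitrogen. The only measured step at this aromatic nitrogen is unreadable, so nothing shown points to a direction, and no step beyond the scatter can be foreseen. Compound 3 is accordingly expected to give 60000 nM in this assay, within 20000 nM to 200000 nM, most probably again as a limit. The step expected from this change is a step that the limit leaves unreadable from compound 2 to compound 3.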

Compound 3, half-maximal inhibitory concentration: 12700 nM
Compound 3: the middle estimate sits 4.7-fold (0.67 log units) above what was measured, and the stated range ends above it.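

Working notes: the aromatic nitrogen is a place where the aryl group can change the read-out, which the first pair could not show. In this assay, 2,4,6-trimethylphenyl in place of 2,4-dinitrophenyl gives an at least 3.9-fold lower number from compound 2 to compound 3 (0.59 log units; beyond the scatter), and 2,4,6-trimethylphenyl in place of 5-chloro-2-methylphenyl gives an at least 3.9-fold lower number from compound 1 to compound 3 (0.59 log units; beyond the scatter). Compound 3 alone has a number rather than a limit, so both steps give only a minimum size: the limit of > 50000 nM in this assay, at which 2 of the 3 values shown sit.

It remains open whether the lower number needs all three methyl groups of 2,4,6-trimethylphenyl, since the three aryl groups shown differ in several substituents at once. Plain phenyl and 2,6-dimethylphenyl would address that, while 4-aminophenyl or 4-carboxyphenyl would show whether an amine or a carboxylic acid is tolerated on this ring.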